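Removing the fluorine from a stilbene Nrf2 activator

The source may hold more compounds than are shown below. What is called first, only, known or untested is meant among the compounds shown, and "the series" means these compounds.

Three stilbenes have been measured in an assay on HepG2 cells for activation of nuclear factor erythroid 2-related factor 2 (Homo sapiens), read by a luciferase reporter, with a stated time of 5 h; a lower number here means that less compound is needed, a higher number that more compound is needed for the effect. Compound 1 `COc1cccc(/C=C/c2ccc(F)cc2)c1` gives 6000 nM, compound 2 `COc1cccc(/C=C/c2cccc(F)c2)c1OC` gives 1900 nM, and compound 3 `COc1cccc(/C=C/c2ccc(F)cc2)c1OC` gives 2900 nM. Among these three numbers compound 3 stands second highest: its value and that of compound 2 lie within the scatter of each other, while the gap to compound 1 is beyond it. Among the measured compounds shown here, the only single change that has been measured is a 2.1-fold lower number from compound 1 to compound 3 (0.32 log units; beyond the scatter), a modest shift.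

Compound 4 `COc1cccc(/C=C/c2ccccc2)c1OC` differs from compound 3 by hydrogen in place of fluoro on an aromatic carbon. For the measured compounds named here, no measured step concerns the loss of a fluorine; the change from compound 1 to compound 3 touches a different ring and a different group, and compounds 2 and 3 together show only that shifting the fluorine around its ring leaves the numbers within the scatter. There is therefore no basis for expecting a step beyond the scatter in this assay in either direction.

On that reasoning the step from compound 3 to compound 4 is expected to be a 1.2-fold higher number from compound 3 to compound 4 (0.08 log units; within the scatter). Compound 4 is estimated to give 3500 nM, in a range from 1500 nM to 8000 nM.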

Compound 4, half-maximal effective concentration: 4700 nM
Compound 4: middle estimate off by 1.3-fold (0.13 log units), on the low side; measured number inside the range.
By their numbers in this assay, from the lowest: compounds 2, 3, 4 and 1 (each within the scatter of the next, the first and the last beyond it).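

Taking the fluoro off the aromatic carbon para to a large group, with hydrogen entering in its place, gives in this assay a 1.6-fold higher number from compound 3 to compound 4 (0.21 log units; within the scatter), so at this position the change cannot be told apart from repeat-measurement noise, and the compound without fluorine still gives a measurable number. The same exchange read from the other fluorine-bearing compound gives a 2.5-fold higher number from compound 2 to compound 4 (0.39 log units; beyond the scatter), a modest step, so whether the loss of fluorine registers depends on which fluorine-bearing compound serves as the reference, although those two references lie within the scatter of each other and this difference should not be read as a firm effect of where the fluorine sits. No independent measurement is available to explain either step.

The compounds shown leave open whether any other group at this position, such as chloro, trifluoromethyl, a nitrile or an amine, would move the number further than fluoro or hydrogen does. They also leave open whether the second methoxy group has the same effect on the core without fluorine as it has on the fluorine-bearing one.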